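Chloro for methoxy on the benzyl arm of compound 1

The compounds below may be only part of what the source reports. "The series", "measured", "known", "first", "only" and "open" are said of these compounds alone.

Measured compounds:
compound 1, `COc1ccc(Cn2cc(/C=N\NC(=O)c3c[nH]c4ccccc34)c3ccccc32)cc1`: 41600 nM
compound 2, `COc1ccc(Cn2cc(/C=N\NC(=O)c3c[nH]c4ccc(Br)cc34)c3ccc(F)cc32)cc1`: 45500 nM
compound 3, `COc1ccc(Cn2cc(/C=N\NC(=O)c3cn(C)c4ccccc34)c3ccc(F)cc32)cc1`: 55800 nM

Of the compounds shown here, three with a shared core have been tested in a functional assay on MIA PaCa-2 cells (Homo sapiens) for cytotoxicity; a lower number here means a stronger inhibitor, a higher number a weaker inhibitor. Compound 1 gives the lowest of the three numbers, but its gaps to compound 2 and to compound 3 both lie within the scatter, so no order among the three can be read from them. Among the compounds with values here, the one single-place step that was measured, a 1.2-fold higher number from compound 2 to compound 3 (0.09 log units; within the scatter), exchanges the group on the carbonyl carbon and is itself within the scatter.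

Compound 4, `O=C(N/N=C\c1cn(Cc2ccc(Cl)cc2)c2ccccc12)c1c[nH]c2ccccc12`, has not been measured. It differs from compound 1 by chloro in place of methoxy on an aromatic carbon; cut one bond further out, 4-methoxybenzyl becomes 4-chlorobenzyl. Within the data shown here, no measured step touches this part of the molecule, and the only step that exists, on the carbonyl side, was flat. Nothing in the data therefore points to a move in either direction for compound 4, and the expected step is a 1.0-fold higher number from compound 1 to compound 4 (0.00 log units; within the scatter), within the scatter. For compound 4 the estimated value in this assay is 42000 nM, with an expected range from 15000 nM to 110000 nM.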

Compound 4, half-maximal inhibitory concentration: 44300 nM
Compound 4: the middle estimate sits 1.1-fold (0.02 log units) below what was measured; the range from low to high includes it.
By their numbers in this assay, from the lowest: compounds 1, 4, 2 and 3 (each within the scatter of the next).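

In this assay, within the data shown here, the exchange of 4-methoxybenzyl for 4-chlorobenzyl gives a 1.1-fold higher number from compound 1 to compound 4 (0.03 log units; within the scatter) and so supplies the first measured step on the benzyl arm, a part of the molecule that the earlier step on the carbonyl side left untouched. At this position, on the core of compound 1, the oxygen of the methoxy and its hydrogen-bond acceptor can give way to chloro while the two numbers stay within the scatter of each other, so this arm, like the carbonyl side, has so far shown only a flat step. No available evidence bears on what lies behind this result.

From the compounds shown here alone, what remains open is whether a quite different group at this place, such as an amine, a carboxylic acid or a longer chain such as butoxy, would give a step beyond the scatter. It is also open whether the chloro exchange would stay as flat on the fluorinated core of compound 2 and compound 3, and the four compounds shown do not yet identify any part of the molecule on which the number depends.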